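This account rests on a few compounds, and the source may have more. Where it says the series, first, only, none or still open, it means among the compounds named here.

Compound 1 `O=c1cc(/C=N\c2ccc(O)cc2)c2ccc(OCc3ccccc3)cc2o1` gives the highest number of the three measured compounds in a functional assay, read by spectrophotometry, with a stated time of 5 min (on this read-out lower numbers stand for stronger inhibition and higher numbers for weaker inhibition), namely 525000 nM. Compound 3 `O=c1cc(/C=N\c2ccc(O)cc2)c2c(OCc3ccccc3)cc(OCc3ccccc3)cc2o1` carries benzyloxy in place of hydrogen on an aromatic carbon and gives 249000 nM in this assay, a step of a 2.1-fold lower number from compound 1 to compound 3 (0.32 log units; beyond the scatter). Compound 2 `N/N=C\c1cc(=O)oc2cc(OCc3ccccc3)cc(OCc3ccccc3)c12` gives 36500 nM in this assay, and the step of a 6.8-fold higher number from compound 2 to compound 3 (0.83 log units; beyond the scatter) goes with 4-hydroxyphenyl in place of amino on the double-bonded nitrogen.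

Compound 4 `O=c1cc(/C=N\c2ccccc2O)c2ccc(OCc3ccccc3)cc2o1` differs from compound 1 in one place: 2-hydroxyphenyl in place of 4-hydroxyphenyl on a double-bonded nitrogen. Going by the values given here, neither measured step touches this kind of change; the only step at that nitrogen swapped the whole hydroxyphenyl group for amino, not the position of the hydroxyl on the ring. Without a comparable step, no shift beyond the scatter is expected in this assay. Compound 4 is therefore estimated at 500000 nM, with a range from 150000 nM to 1500000 nM, which amounts to an expected step of a 1.1-fold lower number from compound 1 to compound 4 (0.02 log units; within the scatter).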

Compound 4, half-maximal inhibitory concentration: 469000 nM
Compound 4: the middle estimate sits 1.1-fold (0.03 log units) above what was measured; measured number inside the range.
By their numbers in this assay, from the lowest: compound 2; then compounds 3, 4 and 1 (each within the scatter of the next, the first and the last beyond it).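

In this assay, moving from 4-hydroxyphenyl to 2-hydroxyphenyl on the double-bonded nitrogen gives a 1.1-fold lower number from compound 1 to compound 4 (0.05 log units; within the scatter). The earlier step at this nitrogen replaced the whole hydroxyphenyl group with amino, whereas this one keeps the group and changes only where the hydroxyl sits on the ring, and on the core of compound 1 this read-out does not separate the two placements. No supporting data are available to explain why the two compounds read alike.

On these data alone, it remains open whether the two placements would also read alike on the core of compound 3, with its added benzyloxy. The compounds shown also leave open how this ring would read with a methoxy group or a carboxylic acid in place of the hydroxyl.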